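The compounds below may be only part of what the source reports. "The series", "measured", "known", "first", "only" and "open" are said of these compounds alone.

Measured compounds:
- compound 1, `OC[C@H]1O[C@@H](n2cnc3c(NCc4ccc(Br)cc4)ncnc32)[C@H](O)[C@@H]1O`, > 166000 nM
- compound 2, `COc1cccc(CNc2ncnc3c2ncn3[C@@H]2O[C@H](CO)[C@@H](O)[C@H]2O)c1OC`, "not determined" (no result reported)
- compound 3, `OC[C@H]1O[C@@H](n2cnc3c(NCc4ccc(F)cc4F)ncnc32)[C@H](O)[C@@H]1O`, > 166000 nM

These three compounds share one core and differ only in the group carried on a saturated chain carbon bound to a nitrogen on an aromatic ring. In a functional assay on G-361 cells (Homo sapiens) for antiproliferative activity, with a stated time of 72 h (a lower number here means a stronger inhibitor, a higher number a weaker inhibitor), compound 1 gives > 166000 nM, which is a limit of the assay and not a number. In this assay compound 3 likewise gives > 166000 nM, again a limit and not a number. For compound 2 the result in this assay is "not determined" (no result reported). Compound 3 therefore stands only at a limit, and the step that the two limits leave unreadable from compound 1 to compound 3 cannot be read, since both ends are limits.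

Compound 4, `OC[C@H]1O[C@@H](n2cnc3c(NCc4cccc(C(F)(F)F)c4)ncnc32)[C@H](O)[C@@H]1O`, carries a different group at the same place: 3-(trifluoromethyl)phenyl in place of 2,4-difluorophenyl on a saturated chain carbon bound to a nitrogen on an aromatic ring. Among the compounds with values here, no measured step gives a readable size for a change of this kind, and the only guidance is that (the limit of > 166000 nM in this assay, at which 2 of the 3 values shown sit), so no shift beyond the scatter can be argued in either direction. The step of a number no higher from compound 3 to compound 4 (the limit leaves the size open) is accordingly expected to be small. Compound 4 is expected to give about 166000 nM in this assay, within a range from 40000 nM to 200000 nM, most likely reported once more as a limit rather than a number.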

Compound 4, half-maximal inhibitory concentration: > 166000 nM
Compound 4 ended at the assay's limit (the forecaster's own chance of this, stated with the estimate: 85%); the middle value lies on the limit itself.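

In this assay compound 4 gives > 166000 nM, again a limit and not a number. The steps to compound 4 from compound 1 and from compound 3 cannot be read, since both ends of each are limits. The compounds shown leave open whether swapping these groups changes activity at all, with the results stopping at one point: the limit of > 166000 nM in this assay, at which 3 of the 4 values shown sit.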